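Notes on the step from compound 1 to compound 4

A few compounds are considered here, and "the series" means these few. Any claim that something is new, unique, unknown or untested is made for them only; others in the source may bear on it.

In a functional assay for inhibition, with Homo sapiens as the target (a lower number here means a stronger inhibitor, a higher number a weaker inhibitor), compound 1 (`COc1cc(OC)c(C(=O)/C=C/c2ccc(Cl)cc2)c(OC)c1`) gives 970 nM, level within the scatter with compound 3 (`COc1cc(OC)c(C(=O)/C=C/c2ccncc2)c(OC)c1`) at 592 nM. Within the data shown here, compound 2 (`COc1cc(OC)c(C(=O)/C=C/c2ccc([N+](=O)[O-])cc2)c(OC)c1`) gives 407 nM, the only number clearly lower than that of compound 1. Compound 4 (`COc1cc(OC)c(C(=O)/C=C/c2cnccn2)c(OC)c1`) differs from compound 1 as follows: pyrazin-2-yl in place of 4-chlorophenyl on a double-bonded chain carbon bound to a double-bonded chain carbon. Among the measured compounds shown here, the closest precedent is the exchange for pyridin-4-yl, a 1.6-fold lower number from compound 1 to compound 3 (0.21 log units; within the scatter), which stays within the scatter. The nitro exchange, a 2.4-fold lower number from compound 1 to compound 2 (0.38 log units; beyond the scatter), is modest and alters only the group on the ring. Both point the same way, so a small drop in this assay is expected, probably not beyond the scatter. The expected step is a 1.6-fold lower number from compound 1 to compound 4 (0.21 log units; within the scatter). Compound 4 is estimated at 600 nM, with an expected range of 280 nM to 1300 nM.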

Compound 4, half-maximal inhibitory concentration: 693 nM
The estimate for compound 4 lay 1.2-fold (0.06 log units) below the measured number; the range from low to high includes it.
By their numbers in this assay, from the lowest: compounds 2, 3, 4 and 1 (each within the scatter of the next, the first and the last beyond it).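

At this place, on a double-bonded chain carbon bound to a double-bonded chain carbon, pyrazin-2-yl can replace 4-chlorophenyl in this assay with no change beyond the scatter (a 1.4-fold lower number from compound 1 to compound 4 (0.15 log units; within the scatter)). Pyrazin-2-yl and pyridin-4-yl also read level (a 1.2-fold higher number from compound 3 to compound 4 (0.07 log units; within the scatter)), so a ring with 2 hetero atoms separates from neither compound 1 nor compound 3. No supporting data bear on why these numbers stay level.

Still open, from the compounds shown here alone, is how an amine or a carboxylic acid on the aromatic ring would compare with the nitro group of compound 2. A non-aromatic ring such as piperidine at this place also remains untested in the compounds shown.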